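A few compounds are considered here, and "the series" means these few. Any claim that something is new, unique, unknown or untested is made for them only; others in the source may bear on it.

Working notes on the series. Compound 1 `O=C(O)COc1cccc(CCCn2cc(C(c3ccccc3)c3ccccc3)ccc2=O)c1` gives 42 nM in an assay on HEK293 cells for displacement of a labelled ligand from prostaglandin D2 receptor 2 (Homo sapiens), read by scintillation counting, with a stated time of 2 h (on this read-out lower numbers stand for stronger inhibition and higher numbers for weaker inhibition), the highest number among the three measured compounds. Compound 2 `O=C(O)COc1cccc(CCCn2cc(C(c3ccc(F)cc3)c3ccc(F)cc3)ccc2=O)c1` gives 11 nM in this assay, and compound 3 `COc1ccc(C(=O)N(CCCc2cccc(OCC(=O)O)c2)CCC(c2ccccc2)c2ccccc2)cc1` gives 5.5 nM; both gaps from compound 1 lie beyond the scatter. Compound 4 `CCC(Oc1cccc(CCCn2cc(C(c3ccccc3)c3ccccc3)ccc2=O)c1)C(=O)O` has not been measured. It differs from compound 1 by ethyl in place of hydrogen on a saturated chain carbon bound to a carbonyl carbon and an oxygen on an aromatic ring. No measured pair shows this change, so its effect cannot be read from the shown numbers. The step from compound 1 to compound 4 is expected to be small, in either direction, and most likely not beyond the scatter. Compound 4 is therefore estimated at 30 nM, within a range of 8 nM to 110 nM, an expected step of a 1.4-fold lower number from compound 1 to compound 4 (0.15 log units; within the scatter).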

Compound 4, half-maximal inhibitory concentration: 502 nM
Compound 4: the middle estimate sits 17-fold (1.22 log units) below what was measured, outside the stated range (above it).
By their numbers in this assay, from the lowest: compounds 3 and 2 (each within the scatter of the next); then compound 1; then compound 4.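

Ethyl in place of hydrogen on the saturated chain carbon bound to a carbonyl carbon and an oxygen on an aromatic ring gives, in this assay, a 12-fold higher number from compound 1 to compound 4 (1.08 log units; beyond the scatter). Among these compounds, the earlier compounds all carry carboxymethoxy, so this is the first sign that the number responds strongly to substitution at this carbon, and the change to 1-carboxypropoxy weakens inhibition on the core of compound 1. Nothing at hand accounts for the size of this step.

The compounds shown leave open whether methyl at this carbon would give a step of similar size. They also leave open whether ethyl here would have the same effect on the cores of compound 2 and compound 3.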